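From Methyl to Ethoxy on a Thiol-Bearing Core

The compounds below may be only part of what the source reports. "The series", "measured", "known", "first", "only" and "open" are said of these compounds alone.

In a functional assay (a higher number here means a weaker inhibitor, a lower number a stronger inhibitor), compound 1 `Cc1ccc2nc(NCCS)sc2c1` reads 4040000 nM while compound 2 `Cc1ccc2nc(S)sc2c1` reads 76700 nM and so holds the lower of the two numbers. Compound 3 `CCOc1ccc2c(c1)sc(=N)n2CCSS(=O)(=O)O` also carries an ethoxy group, but compound 3 is entered as "nd(insoluble)" (no result reported) and no number was reported for it, so it offers no comparison.

For the measured compounds named here, the only measured step is a 53-fold lower number from compound 1 to compound 2 (1.72 log units; beyond the scatter) and it is large. That step, however, concerns sulfanyl in place of (2-sulfanylethyl)amino on an aromatic carbon, and the methyl group is present on both sides of it.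

Compound 4 `CCOc1ccc2nc(S)sc2c1` has not yet been measured. It departs from compound 2 through ethoxy in place of methyl on an aromatic carbon and nothing else changes. Going by the values given here, no measured pair shows this exchange, so the large step gives no size for it and no direction either.

The expectation therefore stays close to compound 2 at 76700 nM with no step beyond the scatter foreseen in this assay for this change. The estimated change is a 1.2-fold lower number from compound 2 to compound 4 (0.07 log units; within the scatter) and a wide margin is expected around it. For compound 4 the expected value is 65000 nM with an estimated range from 16000 nM to 260000 nM at this stage.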

Compound 4, half-maximal inhibitory concentration: 88400 nM
For compound 4 the middle estimate is 1.4-fold (0.13 log units) below the measured one; measured number inside the range.
By their numbers in this assay, from the lowest: compounds 2 and 4 (each within the scatter of the next); then compound 1.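

The exchange on this aromatic carbon, meta to a fused ring and para to a fused ring, now has a measured size in this assay: a 1.2-fold higher number from compound 2 to compound 4 (0.06 log units; within the scatter). Ethoxy, with 3 heavy atoms and 1 hydrogen-bond acceptor, therefore stands in place of methyl, with 1 heavy atom and no acceptor, without a difference that this assay can separate from scatter, while the sulfanyl group on the shared core stays the same; the earlier step, a 53-fold lower number from compound 1 to compound 2 (1.72 log units; beyond the scatter), had kept methyl fixed and so could say nothing about this position. Nothing available accounts for this result, so the reading remains a plain observation about these two compounds.

The compounds shown leave open whether this position would tolerate groups other than these two, such as an amine, a carboxylic acid or a longer alkoxy chain like butoxy, as evenly as it does ethoxy. They also leave open whether the same exchange would read alike when (2-sulfanylethyl)amino replaces sulfanyl on the core, since only the sulfanyl pair gives a comparison.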